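Swapping 2-Fluorophenyl for 4-Nitrophenyl in Compound 1

The source may report more compounds than this note shows. Statements on the series, on what has been measured and on what is new or still open speak of the compounds shown alone.

In a physicochemical assay, with a stated time of 6 min (a lower number here means a stronger inhibitor, a higher number a weaker inhibitor), compound 1 `O=C(Nc1nc(-c2cc3ccccc3o2)cs1)Nc1ccccc1F` gives 2630 nM. Compound 3 `O=C(Nc1ccccc1)Nc1nc(-c2cc3cc([N+](=O)[O-])ccc3o2)cs1` gives 183000 nM, so compound 1 holds the lower of the two actual numbers, by a gap well beyond the usual scatter. Compound 2 `Cc1ccc(NC(=O)Nc2nc(-c3cc4cc(Br)ccc4o3)cs2)cc1` gives > 200000 nM, which is a limit of the assay and not a number.

Compound 4 `O=C(Nc1ccc([N+](=O)[O-])cc1)Nc1nc(-c2cc3ccccc3o2)cs1` has not yet been measured. It keeps the core of compound 1 but has 4-nitrophenyl in place of 2-fluorophenyl on an amide-type nitrogen. Among the measured compounds shown here, no two measured compounds differ in only one place, so no measured step shows what such a swap does. For the measured compounds named here, the only hint is indirect: compound 3, the one measured compound carrying a nitro group, gives 183000 nM, although it differs from compound 1 in more than one place. A weaker inhibitor therefore seems likelier than a stronger one. An estimated step of a 7.6-fold higher number from compound 1 to compound 4 (0.88 log units; beyond the scatter) is expected, towards a higher number. For compound 4 the expected value is 20000 nM, with an estimated range of 2500 nM to 150000 nM.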

Compound 4, half-maximal inhibitory concentration: 19300 nM
Compound 4: middle estimate off by 1.0-fold (0.02 log units), on the high side; low and high end bracket the measured number.
By their numbers in this assay, from the lowest: compound 1; then compound 4; then compound 3. At a limit, above all of these: compound 2.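

Among the compounds shown here, this is the first step in the set that changes one place only, so the group on the amide-type nitrogen can now be judged by itself. In this assay, 4-nitrophenyl in place of 2-fluorophenyl gives a 7.3-fold higher number from compound 1 to compound 4 (0.87 log units; beyond the scatter), so on the core of compound 1 this swap weakens inhibition beyond the scatter. Even so, compound 4 still gives a real number, which shows that this position can carry 4-nitrophenyl without the value reaching a limit.

Still open, as far as these compounds go, is whether the step comes from gaining the nitro group or losing the fluorine, and what 4-aminophenyl or a ring bearing a carboxylic acid would give at this position on the same core. Compound 2 gives only a limit and not a number, so it cannot be ranked: the limit of > 200000 nM in this assay, at which 1 of the 4 values shown sits.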